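The source may hold more compounds than are shown below. What is called first, only, known or untested is meant among the compounds shown, and "the series" means these compounds.

Of the compounds shown here, two with a shared core have so far been measured in an assay on isolated protein for antagonist activity at prostaglandin E2 receptor EP1 subtype (Homo sapiens), read by reporter gene assay; a lower number here means a stronger inhibitor, a higher number a weaker inhibitor. Compound 1 `COc1ccc2c(-c3ccccc3)nn(-c3nc(C(=O)O)cs3)c2c1` gives 1.1 nM in this assay. Compound 2 `O=C(O)c1csc(-n2nc(-c3ccc(Cl)cc3)c3ccccc32)n1` gives 12 nM in this assay, which is the higher of the two numbers; the gap between compound 2 and compound 1 lies beyond the scatter of repeated measurements. Within the data shown here, no step between measured compounds that differ in a single place is available, so the two values stand alone without a comparison of that kind.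

Compound 3 `CC1CCN(c2nn(-c3nc(C(=O)O)cs3)c3ccccc23)CC1` has not yet been measured. It differs from compound 2 in one place: 4-methylpiperidin-1-yl in place of 4-chlorophenyl on an aromatic carbon. An aromatic ring of carbon only leaves, and a non-aromatic ring with one hetero atom enters, on an aromatic carbon of the five-membered aromatic ring with two nitrogen that belongs to the fused system. Among the measured compounds shown here, nothing among the measured compounds shows how such an exchange acts in this assay, so any expectation rests on the two values alone and on the nature of the change. A weakening step of moderate size, a 5.0-fold higher number from compound 2 to compound 3 (0.70 log units; beyond the scatter), is expected. Compound 3 is estimated at 60 nM in this assay, within a range from 10 nM to 400 nM.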

Compound 3, half-maximal inhibitory concentration: 32 nM
Compound 3: the middle estimate sits 1.9-fold (0.27 log units) above what was measured; low and high end bracket the measured number.
By their numbers in this assay, from the lowest: compound 1; then compound 2; then compound 3.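

In this assay, among these compounds, the exchange of 4-chlorophenyl for 4-methylpiperidin-1-yl on this aromatic carbon of the five-membered aromatic ring with 2 nitrogen gives a 2.7-fold higher number from compound 2 to compound 3 (0.43 log units; beyond the scatter), a modest step and the first reading of any change at this place. Compound 3 still gives 32 nM, so a six-membered aromatic ring of carbon only is not needed here for a value of this order, although the non-aromatic ring with 1 hetero atom scores somewhat worse even though both groups hold 7 heavy atoms. Nothing available accounts for the size or direction of this step.

A single exchange changes the ring type, the ring nitrogen and the substituent at once, so the compounds shown do not reveal which of these goes with the higher number; a plain phenyl, an unsubstituted piperidin-1-yl or a morpholine ring at this place would begin to separate them. As far as these compounds go, it also stays open whether the methoxy group of compound 1 would shift the value when paired with 4-methylpiperidin-1-yl.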